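Aminocyano-spirooxindole series: swapping the aryl on the triazole

The compounds below may be only part of what the source reports. "The series", "measured", "known", "first", "only" and "open" are said of these compounds alone.

Three spiro compounds of one shared core have been measured in a functional assay on MCF7 cells (Homo sapiens) for antiproliferative activity, read by MTT assay, with a stated time of 48 h; a lower number here means a stronger inhibitor, a higher number a weaker inhibitor. Compound 1 `N#CC1=C(N)Oc2c(c3nc4ccccc4nc3c3ccccc23)C12C(=O)N(Cc1cnnn1-c1ccccc1Cl)c1ccccc12` carries a 2-chlorophenyl on the triazole nitrogen; in this assay compound 1 gives only a limit, > 50000 nM. Compound 2 `N#CC1=C(N)Oc2c(c3nc4ccccc4nc3c3ccccc23)C12C(=O)N(Cc1cnnn1-c1ccc(Cl)c(Cl)c1)c1ccccc12` carries a 3,4-dichlorophenyl there; in this assay compound 2 likewise gives only a limit, > 50000 nM. The step that the two limits leave unreadable from compound 1 to compound 2 therefore cannot be read. Within the data shown here, compound 3 `CCOc1ccc(-n2nncc2CN2C(=O)C3(C(C#N)=C(N)Oc4c(N)cc5nc6ccccc6nc5c43)c3ccccc32)cc1`, which carries a 4-ethoxyphenyl on the triazole nitrogen and an amino group on the core, is the only compound with an actual number: in this assay compound 3 gives 26800 nM, so it stands as the sole measured point while (the limit of > 50000 nM in this assay, at which 2 of the 3 values shown sit).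

Compound 4 `COc1cc(-n2nncc2CN2C(=O)C3(C(C#N)=C(N)Oc4c(N)cc5nc6ccccc6nc5c43)c3ccccc32)c(OC)cc1Cl` differs from compound 3 in one place: 4-chloro-2,5-dimethoxyphenyl in place of 4-ethoxyphenyl on an aromatic nitrogen. Among the measured compounds shown here, no measured step bears on this change, since the one step available is unreadable. With nothing pointing either way, the step of a 1.1-fold higher number from compound 3 to compound 4 (0.05 log units; within the scatter) is expected to stay within the usual scatter, and compound 4 is expected to give about 30000 nM in this assay, plausibly between 8000 nM and 50000 nM, with a real chance that only a limit is reported.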

Compound 4, half-maximal inhibitory concentration: > 50000 nM
Compound 4 was reported as a limit; the forecaster's own chance of this, stated with the estimate: 35%; at least 1.6-fold (0.22 log units) between middle value and limit.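

In this assay, 4-chloro-2,5-dimethoxyphenyl in place of 4-ethoxyphenyl on the aromatic nitrogen gives an at least 1.8-fold higher number from compound 3 to compound 4 (0.27 log units; that floor lies within the scatter). Among these compounds, this is the first readable step at this position, but it is only a floor: compound 4 gives a limit, so the true size of the step remains unknown, and the floor alone does not separate the two compounds beyond the scatter. Compound 3 remains the only compound with a measured number, and the other three compounds all end at the same assay limit: the limit of > 50000 nM in this assay, at which 3 of the 4 values shown sit.

The compounds shown leave open what the amino group on the core of compound 3 contributes, since compounds 1 and 2 differ from compounds 3 and 4 in the core as well as in the aryl group and offer no single-place comparison with them. Also open, going by these compounds, is how this assay would read a phenyl on that nitrogen bearing a single methoxy, an amine or a carboxylic acid, and whether any such group would give a number rather than a limit.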